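The compounds below may be only part of what the source reports. "The series", "measured", "known", "first", "only" and "open" are said of these compounds alone.

Within the data shown here, in a functional assay on K562 cells (Homo sapiens) for inhibition, read by MTT assay, with a stated time of 72 h (on this read-out higher numbers stand for weaker inhibition and lower numbers for stronger inhibition), compound 1 (`CCc1ccc(C(C)C)cc1C(=O)/C=C/C(=O)O`) gives 1360 nM and holds the lower of the two numbers measured so far. Compound 2 (`CC(C)c1ccc(C(C)C)c(C(=O)/C=C/C(=O)O)c1`) gives 3280 nM and differs from compound 1 in one place, a methyl in place of hydrogen on a saturated chain carbon bound to an aromatic carbon and a saturated chain carbon. That change produced a 2.4-fold higher number from compound 1 to compound 2 (0.38 log units; beyond the scatter) and counts as a modest step.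

Compound 3 (`CCc1c(C(=O)/C=C/C(=O)O)cc(C(C)C)cc1C(C)C`) keeps all of compound 1 and adds one group: isopropyl in place of hydrogen on an aromatic carbon This is isopropyl in place of hydrogen on an aromatic carbon, ortho to an ethyl group and meta to both a (2-carboxyethenyl)carbonyl group and an isopropyl group.

Among the measured compounds shown here, the single measured step is only a loose guide, since it sits in a different place, and no measurement yet shows what a new group on this aromatic carbon does. A modest step toward a higher number in this assay therefore seems the most reasonable expectation, similar in size to the one measured. The expected change is a 2.2-fold higher number from compound 1 to compound 3 (0.34 log units; beyond the scatter) on this estimate. Compound 3 is expected near 3000 nM with an estimated range from 1100 nM to 8000 nM as its limits.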

Compound 3, half-maximal inhibitory concentration: 5100 nM
Beside the measured number, compound 3's estimate is 1.7-fold (0.23 log units) below it; low and high end bracket the measured number.
By their numbers in this assay, from the lowest: compound 1; then compounds 2 and 3 (each within the scatter of the next).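

Among these compounds, the compounds before this one showed only a change on a saturated chain carbon, so this is the first look at what a new group does on this aromatic carbon of the ring, ortho to an ethyl group. In this assay, putting isopropyl in place of hydrogen there gives a 3.8-fold higher number from compound 1 to compound 3 (0.57 log units; beyond the scatter), and a higher number here means weaker inhibition, so this carbon does not accept the added isopropyl without a measurable loss. The step is modest but lies beyond the usual scatter of repeated measurements, which makes it a real difference between these two compounds, though no measurement available here explains why the number rises.

The compounds shown leave open whether this loss is specific to isopropyl or would come with any group placed on this carbon, as only one replacement for hydrogen can be read here. A smaller methyl, a single fluorine atom or an amine on the same aromatic carbon, each compared directly with compound 1, would show whether the number depends on which group sits there.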